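Methoxy for hydrogen on the fused ring of compound 3

A few compounds are considered here, and "the series" means these few. Any claim that something is new, unique, unknown or untested is made for them only; others in the source may bear on it.

Measured so far:
compound 1, `O=c1cc(-c2ccccc2)oc2ccc(N3COc4c(cccc4[N+](=O)[O-])C3)cc12`, 72.9%
compound 2, `O=c1cc(-c2ccccc2)oc2cc(N3COc4c(Br)cccc4C3)ccc12`, 19.5%
compound 3, `O=c1cc(-c2ccccc2)oc2ccc(N3COc4ccccc4C3)cc12`, 92.7%

In a functional assay on MCF7 cells (Homo sapiens) for inhibition, read by MTT assay, with a stated time of 48 h, tested at 60 ug/mL (a higher number here means more inhibition of growth at the concentration tested, a lower number less inhibition of growth), compound 3 stands highest of the three. Compound 1 is nearest to it, and the step of a number 19.8 percentage points higher from compound 1 to compound 3 (beyond the scatter) separates the two, a hydrogen in place of nitro on an aromatic carbon. Compound 2 lies far below compound 3; the two differ in more than one place, so only their two values can be set side by side.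

Compound 4, `COc1cccc2c1OCN(c1ccc3oc(-c4ccccc4)cc(=O)c3c1)C2`, differs from compound 3 by methoxy in place of hydrogen on an aromatic carbon. Going by the values given here, the one measured step that bears on this place is a number 19.8 percentage points higher from compound 1 to compound 3 (beyond the scatter), where a nitro group at the same position gave the lower number. Among the compounds with values here, compound 2 carries bromo on its own fused ring, but no single step links it to compound 3. On this basis a modest fall is expected for compound 4, a number 14.7 percentage points lower from compound 3 to compound 4 (beyond the scatter). The estimate for compound 4 in this assay is 78%, with a range from 55% to 95%.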

Compound 4, percent growth inhibition at one concentration: 91.9%
Compound 4: the middle estimate sits 13.9 percentage points below what was measured; the range from low to high includes it.
By their numbers in this assay, from the lowest: compound 2; then compound 1; then compounds 4 and 3 (each within the scatter of the next).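

Methoxy on this aromatic carbon leaves the reading in this assay where hydrogen put it, with a number 0.8 percentage points lower from compound 3 to compound 4 (within the scatter), so a substituent here does not by itself bring the lower number seen with nitro. Measured against nitro at the same position, methoxy gives a number 19 percentage points higher from compound 1 to compound 4 (beyond the scatter), which places the lower number of this pair with nitro alone among the three groups seen at this carbon. No measurement available here gives a reason for the difference between methoxy and nitro.

Going by these compounds, whether an amine, a carboxylic acid or a longer alkoxy chain on this carbon would read with compound 3 and compound 4 or with compound 1 remains open. On these data alone, compound 2 differs from the others in more than one place, so its steps cannot be read, and what bromo alone does on this carbon also remains open.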